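The compounds below may be only part of what the source reports. "The series", "measured", "known", "first", "only" and "open" are said of these compounds alone.

Measured so far:
- compound 1, `CCCCNc1nc(N)nc(C)c1CCCCO`: 1310 nM
- compound 2, `CCCCNc1nc(N)nc(C)c1CCCn1c(C)nc2ccccc21`: 366 nM
- compound 3, `CCCCNc1nc(N)nc(C)c1C#CCN1CCCCC1`: 3790 nM

In an assay on HEK293 cells for agonist activity at Toll-like receptor 8 (Homo sapiens), read by spectrophotometry (a higher number here means that more compound is needed for the effect, a lower number that less compound is needed), compound 1 gives 1310 nM, the second highest of the three numbers. Its nearest neighbour is compound 3, whose number is higher by a margin beyond the scatter; the furthest is compound 2, whose number is lower, again beyond the scatter. All three compounds share the same core and differ only in the chain carried on it.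

The next compound in the series is compound 4, `CCCCNc1nc(N)nc(C)c1CCCC`, still to be measured in this assay. It differs from compound 1 by hydrogen in place of hydroxy on a saturated chain carbon, four bonds along the chain from an aromatic carbon, so the 3-hydroxypropyl arm becomes a plain propyl arm. Among the measured compounds shown here, no measured pair in this set isolates that change, so the size of the step rests on judgement alone. The two neighbours of compound 1 show that the chain end can move the number in either direction by a clear margin.

For compound 4 the expectation is a moderate rise in the number, with the step from compound 1 to compound 4 estimated at a 2.3-fold higher number from compound 1 to compound 4 (0.36 log units; beyond the scatter). The estimated value for compound 4 is 3000 nM, within a range of 1000 nM to 9000 nM.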

Compound 4, half-maximal effective concentration: 780 nM
Estimate against measurement, compound 4: 3.8-fold (0.59 log units) above; the whole stated range lies above it.
By their numbers in this assay, from the lowest: compound 2; then compounds 4 and 1 (each within the scatter of the next); then compound 3.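

In this assay, the step of a 1.7-fold lower number from compound 1 to compound 4 (0.23 log units; within the scatter) shows that the hydroxy at the end of the 3-hydroxypropyl arm can give way to hydrogen without a shift that stands clear of the usual scatter. On this pair, the hydroxy on that saturated chain carbon is not required for a number of this size, and the plain propyl arm does as well as the 3-hydroxypropyl arm, even though one hydrogen-bond donor and one hydrogen-bond acceptor leave with the hydroxy. This reading rests on a single pair, and no measurement on hand speaks to what lies behind it.

Still open, as far as these compounds go, is whether the chain end accepts other groups in this way: an amine, a carboxylic acid or a methoxy group in place of the hydroxy might move the number by a clear margin, and a longer chain such as butyl or pentyl in place of propyl might do the same. Also open, from the compounds shown here alone, is whether the exchange of hydroxy for hydrogen would give a similar step on a hydroxymethyl or 2-hydroxyethyl arm.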